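A few compounds are considered here, and "the series" means these few. Any claim that something is new, unique, unknown or untested is made for them only; others in the source may bear on it.

Measured compounds:
compound 1 `COc1cccc(OC)c1OCCNCCOc1ccccc1OCc1ccccc1Cl`: in an assay on CHO cells for displacement of a labelled ligand from Alpha-1A adrenergic receptor (Homo sapiens) (on this read-out lower numbers stand for stronger inhibition and higher numbers for weaker inhibition), compound 1 gives 1.41 nM
compound 2 `COc1cccc(OC)c1OCCNCCOc1ccccc1OCc1cccc(Cl)c1`: compound 2 gives 0.251 nM
compound 3 `COc1cccc(OC)c1OCCNCCOc1ccccc1OCc1ccccc1C`: compound 3 gives 1.59 nM

Compound 3 stands highest of the three numbers, but its gap to compound 1 lies within the scatter; only its distance to compound 2 is beyond it. Compound 4 `COc1cccc(OC)c1OCCNCCOc1ccccc1OCc1ccc(C)cc1` differs from compound 3 by 4-methylphenyl in place of 2-methylphenyl on a saturated chain carbon bound to an oxygen on an aromatic ring. Going by the values given here, no measured step places a group as 4-methylphenyl, so the bearing is indirect. Going from 2-chlorophenyl to 3-chlorophenyl gave a 5.6-fold lower number from compound 1 to compound 2 (0.75 log units; beyond the scatter), the move from 3-chlorophenyl to 2-methylphenyl gave a 6.3-fold higher number from compound 2 to compound 3 (0.80 log units; beyond the scatter), and chloro against methyl on the same aromatic carbon gave a 1.1-fold higher number from compound 1 to compound 3 (0.05 log units; within the scatter). Leaving the 2-methylphenyl arrangement is therefore expected to give a modestly lower number, with wide uncertainty: a 2.7-fold lower number from compound 3 to compound 4 (0.42 log units; beyond the scatter). Compound 4 is estimated at 0.6 nM, within 0.15 nM to 2.5 nM.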

Compound 4, inhibition constant: 2 nM
For compound 4 the middle estimate is 3.3-fold (0.52 log units) below the measured one; low and high end bracket the measured number.
By their numbers in this assay, from the lowest: compound 2; then compounds 1, 3 and 4 (each within the scatter of the next).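

In this assay, 4-methylphenyl in place of 2-methylphenyl leaves the number unchanged within the scatter (a 1.3-fold higher number from compound 3 to compound 4 (0.10 log units; within the scatter)), so moving the methyl does not register here as moving the chloro did. The 4-methylphenyl compound also sits close to the 2-chlorophenyl compound (a 1.4-fold higher number from compound 1 to compound 4 (0.15 log units; within the scatter)) but well away from the 3-chlorophenyl compound (an 8.0-fold higher number from compound 2 to compound 4 (0.90 log units; beyond the scatter)), leaving compound 2 alone among the four. Nothing available bears on why compound 2 stands apart.

Open, from the compounds shown here alone, is whether 3-methylphenyl would match 3-chlorophenyl, and whether 4-chlorophenyl would track 4-methylphenyl. Going by these compounds, a methoxy or fluoro group on this ring is equally open.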